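The compounds below may be only part of what the source reports. "The series", "measured", "known", "first", "only" and "open" are said of these compounds alone.

Measured compounds:
compound 1 `C[C@@H]1CN(c2sc(C(F)(F)F)nc2-c2nc3ccccc3[nH]2)CCN1C(=O)CN1C(=O)OC[C@@H]1c1ccccc1` gives 1380 nM in a functional assay on Venous blood for antagonist activity at C-X-C chemokine receptor type 3 (Homo sapiens), read by flow cytometry, with a stated time of 30 min, in the presence of a further agent that is not named here; on this read-out higher numbers stand for weaker inhibition and lower numbers for stronger inhibition
compound 2 `Cc1nc(C)n(CC(=O)N2CCN(c3sc(C(F)(F)F)nc3-c3nc4ccc(C5CCOCC5)cc4[nH]3)C[C@H]2C)n1` gives 123 nM in this assay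
compound 3 `C[C@@H]1CN(c2sc(C(F)(F)F)nc2-c2nc3cc(Cl)ccc3[nH]2)CCN1C(=O)Cn1cnc2cccnc21` gives 38.5 nM in this assay

Compound 1 stands at the highest number of the three; compound 2 and compound 3 both lie beyond the scatter from it, compound 3 furthest, so compound 1 is the weakest inhibitor of the set.

Compound 4 `Cc1nc(C)n(CC(=O)N2CCN(c3sc(C(F)(F)F)nc3-c3nc4ccccc4[nH]3)C[C@H]2C)n1` differs from compound 1 in one place: 3,5-dimethyl-1H-1,2,4-triazol-1-yl in place of 2-oxo-4-phenyl-1,3-oxazolidin-3-yl on a saturated chain carbon bound to a carbonyl carbon. For the measured compounds named here, no pair of measured compounds isolates this change. Compound 2 carries the same entering group, together with a further change elsewhere, and its number sits far under that of compound 1. A downward step beyond the scatter is expected, a 3.9-fold lower number from compound 1 to compound 4 (0.60 log units; beyond the scatter). Compound 4 is estimated at 350 nM in this assay, with a range from 100 nM to 1200 nM.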

Compound 4, half-maximal inhibitory concentration: 237 nM
Estimate against measurement, compound 4: 1.5-fold (0.17 log units) above; low and high end bracket the measured number.
By their numbers in this assay, from the lowest: compound 3; then compounds 2 and 4 (each within the scatter of the next); then compound 1.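

The step isolates this change on a saturated chain carbon bound to a carbonyl carbon: with the rest of the molecule fixed, 3,5-dimethyl-1H-1,2,4-triazol-1-yl in place of 2-oxo-4-phenyl-1,3-oxazolidin-3-yl gives a 5.8-fold lower number from compound 1 to compound 4 (0.77 log units; beyond the scatter). Hydrogen in place of oxan-4-yl on an aromatic carbon gives a 1.9-fold higher number from compound 2 to compound 4 (0.28 log units; within the scatter), so the distance of compound 2 from compound 1 does not require the oxan-4-yl group. No measurement at hand accounts for either step. Going by these compounds, it remains open whether the two methyl groups are needed, as an unsubstituted 1H-1,2,4-triazol-1-yl at this place would show.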